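Series notes: aryl substitution on the ring amine, compound 3

A few compounds are considered here, and "the series" means these few. Any claim that something is new, unique, unknown or untested is made for them only; others in the source may bear on it.

Measured so far:
Compound 1, `CSc1ccccc1N1CCN(CCCNc2ncccc2C(=O)N(C)C)CC1` — 0.631 nM
Compound 2, `CCCc1ccccc1N1CCN(CCCNc2ncccc2C(=O)N(C)C)CC1` — 0.2 nM

Two compounds of the shared core have numbers in a functional assay for antagonist activity at Alpha-1A adrenergic receptor (Oryctolagus cuniculus); a higher number here means weaker binding, a lower number tighter binding. Compound 1 gives 0.631 nM and compound 2 gives 0.2 nM. Going by the values given here, the one step between them, a 3.2-fold lower number from compound 1 to compound 2 (0.50 log units; beyond the scatter), is the only measured comparison available, and it places compound 2 at the lowest number of the two, with compound 1 the nearest at a higher number beyond the scatter.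

Compound 3, `COc1cc(O)ccc1N1CCN(CCCNc2ncccc2C(=O)N(C)C)CC1`, is not yet measured in this assay. It differs from compound 2 by 4-hydroxy-2-methoxyphenyl in place of 2-propylphenyl on an amine nitrogen in a ring. Among the compounds with values here, no measured step bears on this change directly: the single step from methylsulfanyl to propyl exchanges one group on the aromatic carbon for another without oxygen, whereas here the whole aryl group changes and gains one hydrogen-bond donor and two hydrogen-bond acceptors. Within the data shown here, the only guidance is that the aryl group on the ring amine does move the number, by a modest amount, in the one case measured.

For compound 3 the expectation is a somewhat higher number than compound 2, with wide uncertainty: a 5.0-fold higher number from compound 2 to compound 3 (0.70 log units; beyond the scatter) is the estimated step, giving an estimate of 1 nM with a range from 0.2 nM to 5 nM.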

Compound 3, dissociation constant: 12.6 nM
Compound 3: the middle estimate sits 13-fold (1.10 log units) below what was measured, and the stated range ends below it.
By their numbers in this assay, from the lowest: compound 2; then compound 1; then compound 3.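

In this assay the aryl group on the ring amine proves able to move the number much further than the earlier methylsulfanyl-to-propyl change, a 3.2-fold lower number from compound 1 to compound 2 (0.50 log units; beyond the scatter), had indicated. Placing 4-hydroxy-2-methoxyphenyl on this amine nitrogen gives a 63-fold higher number from compound 2 to compound 3 (1.80 log units; beyond the scatter) and, against the other measured aryl group, a 20-fold higher number from compound 1 to compound 3 (1.30 log units; beyond the scatter), so both steps are large and beyond the scatter, and compound 3 stands highest of the three. The new group brings a hydrogen-bond donor and hydrogen-bond acceptors and contains oxygen, whereas 2-propylphenyl has no donor or acceptor, but these compounds offer no measurement that explains the rise in the number.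

The hydroxy and methoxy groups enter together in compound 3, so the share of the step belonging to each cannot be separated from these three compounds. Plain 2-methoxyphenyl and 4-hydroxy-2-propylphenyl would divide the change between the two groups, while a carboxylic acid or an amine in place of the hydroxy group would show how the number responds to other groups on this aryl ring.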